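Swapping cyclohexyl for 4-methylphenyl on the ring nitrogen

This account rests on a few compounds, and the source may have more. Where it says the series, first, only, none or still open, it means among the compounds named here.

Compounds measured so far:
compound 1, `CN1C(=S)N(C2CCCCC2)C(=O)/C1=C/c1ccc(O)cc1O`, 37600 nM
compound 2, `CN1C(=S)N(C2CCCCC2)C(=O)/C1=C/c1cccc(O)c1O`, 6350 nM
compound 3, `CN1C(=S)N(C2CCCCC2)C(=O)/C1=C/c1ccc(N(C)C)cc1`, 35600 nM

All three were run in an assay for inhibition of NADPH oxidase 4 (Homo sapiens), read by chemiluminescence; a higher number here means a weaker inhibitor, a lower number a stronger inhibitor. On these numbers compound 1 gives the highest value of the three; compound 3 sits within the scatter of it, while compound 2 gives a lower number that lies beyond the scatter. Compound 4, `Cc1ccc(N2C(=O)/C(=C/c3ccc(O)cc3O)N(C)C2=S)cc1`, has not yet been measured in this assay. It differs from compound 1 in one place: 4-methylphenyl in place of cyclohexyl on an amide-type nitrogen in a ring. For the measured compounds named here, no measured pair shows this exchange, so its size is not known from these data. The expectation is a step of modest size, if any, and likely none beyond the scatter, as a 1.5-fold lower number from compound 1 to compound 4 (0.18 log units; within the scatter). Compound 4 is therefore estimated at 25000 nM, with a range from 8000 nM to 80000 nM.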

Compound 4, inhibition constant: 34600 nM
Compound 4: middle estimate off by 1.4-fold (0.14 log units), on the low side; the range from low to high includes it.
By their numbers in this assay, from the lowest: compound 2; then compounds 4, 3 and 1 (each within the scatter of the next).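

For the compounds shown here, all the earlier compounds carried cyclohexyl on the amide-type nitrogen in a ring, so this is the first reading of that position in this assay. Exchanging it for 4-methylphenyl gives a 1.1-fold lower number from compound 1 to compound 4 (0.04 log units; within the scatter) and so, on the core of compound 1, the data do not separate a non-aromatic ring from an aromatic one here. Nothing given here offers an explanation for this result. From the compounds shown here alone, whether the exchange gives the same step on the core of compound 2 remains open. So does the effect of an amine, a carboxylic acid or a longer chain in place of cyclohexyl.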